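A few compounds are considered here, and "the series" means these few. Any claim that something is new, unique, unknown or untested is made for them only; others in the source may bear on it.

Notes on the series around compound 1 `O=S(=O)(Nc1ccc2oc(-c3ccccc3)nc2c1)c1ccc(Cl)c(Cl)c1`. In an assay on isolated protein for inhibition of malate dehydrogenase, mitochondrial (Sus scrofa), with stated times of 45 min and 30 min (on this read-out lower numbers stand for stronger inhibition and higher numbers for weaker inhibition), compound 1 gives > 63000 nM; this is a limit of the assay, not a number. Compound 2 `COc1ccc(Cl)cc1S(=O)(=O)Nc1ccc(-c2nc3ccccc3o2)cc1` in this assay gives > 63000 nM, again only a limit. Compound 3 `C=Cc1ccc(S(=O)(=O)Nc2ccc(-c3nc4ccccc4o3)cc2)cc1` in this assay gives > 63000 nM, also a limit. Among the measured compounds shown here, the one pair differing in a single place, with 4-vinylphenyl in place of 5-chloro-2-methoxyphenyl on a sulfonyl sulfur, gives a step that the two limits leave unreadable from compound 2 to compound 3. Compound 1 therefore stands where every measured value stands: the limit of > 63000 nM in this assay, at which 3 of the 3 values shown sit. Compound 4 `O=S(=O)(Nc1ccc2oc(-c3ccccc3)nc2c1)c1cccc(O)c1` differs from compound 1 by 3-hydroxyphenyl in place of 3,4-dichlorophenyl on a sulfonyl sulfur. For the measured compounds named here, no measured step bears on this exchange; the only step recorded is unreadable, and no value in the set is a number. The expectation for compound 4 in this assay is accordingly a value at or near the limit, the estimated step being a number no higher from compound 1 to compound 4 (the limit leaves the size open). Compound 4 is estimated at 63000 nM, with a range from 20000 nM to 200000 nM, and most probably only a limit will again be reported.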

Compound 4, half-maximal inhibitory concentration: > 63000 nM
Compound 4 gave a limit, no number (the forecaster's own chance of this, stated with the estimate: 75%); the middle value lies on the limit itself.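

Compound 1 and compound 4 each give only a limit, so 3-hydroxyphenyl in place of 3,4-dichlorophenyl yields no readable step: the limit of > 63000 nM in this assay, at which 4 of the 4 values shown sit. The compounds shown leave open which change to the shared core, if any, would give a number in this assay.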